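Notes on compound 3 and growth inhibition

The compounds below may be only part of what the source reports. "The series", "measured", "known", "first", "only" and "open" are said of these compounds alone.

- Compound 1 `Cc1ccccc1Nc1nc(Nc2ccc(N3CCCN(C)CC3)cc2)ncc1Cl`: 6390 nM
- Compound 2 `CN1CCN(c2ccc(Nc3ncc(Cl)c(NCc4ccc(F)cc4)n3)nc2)CC1`: > 100000 nM

In a functional assay on MDA-MB-231 cells (Homo sapiens) for inhibition, read by CCK-8 assay, with a stated time of 48 h (a higher number here means a weaker inhibitor of growth, a lower number a stronger inhibitor of growth), compound 2 stands at > 100000 nM, which is a limit of the assay and not a number. Compound 3 `CC(C)c1ccc(Nc2nc(Nc3ccc(N4CCN(C)CC4)cn3)ncc2Cl)cc1` carries 4-isopropylphenyl in place of 4-fluorobenzyl on a nitrogen on an aromatic ring. Among the compounds with values here, no measured step is available to size this change. Within the data shown here, compound 1 at 6390 nM is the only measured number, and it serves as the rough guide. A large move towards stronger inhibition is expected, with the estimated step of an at least 12-fold lower number from compound 2 to compound 3 (1.09 log units; beyond the scatter). For compound 3 the expected value is 8000 nM, with an estimated range of 2000 nM to 40000 nM.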

Compound 3, concentration for 50% growth inhibition: 7020 nM
Estimate against measurement, compound 3: 1.1-fold (0.06 log units) above, and the stated range covers the measured number.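

On this nitrogen, 4-isopropylphenyl in place of 4-fluorobenzyl turns a read-out at the limit into a measured number in this assay, with a step of an at least 14-fold lower number from compound 2 to compound 3 (1.15 log units; beyond the scatter). The value of compound 2 is a limit of the assay and not a number, so the true size of the step remains unknown: the limit of > 100000 nM in this assay, at which 1 of the 3 values shown sits.

The compounds shown leave open which part of the change carries the step: the loss of the benzyl methylene or the exchange of fluorine for isopropyl. An unsubstituted phenyl on the same nitrogen would help separate the two.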